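The source may hold more compounds than are shown below. What is called first, only, known or untested is meant among the compounds shown, and "the series" means these compounds.

Series notes on the shared core. Among the compounds with values here, compound 2 `O=C(NC1=NC(=O)C2CCCN12)Nc1ccccc1` stands at 4200 nM in a functional assay for inhibition of metabotropic glutamate receptor 5 (Homo sapiens), read by FLIPR and calcium flux (on this read-out lower numbers stand for stronger inhibition and higher numbers for weaker inhibition), the highest of the two numbers measured so far; its nearest neighbour, compound 1 `O=C(NC1=NC(=O)C2CCCN12)Nc1cccc(Cl)c1`, gives 800 nM in this assay. Within the data shown here, the only step between measured compounds is a 5.3-fold higher number from compound 1 to compound 2 (0.72 log units; beyond the scatter), a chloro replaced by hydrogen. Compound 3 `O=C(NC1=NC(=O)C2CCCN12)Nc1ccc(Cl)cc1` has not yet been measured; against compound 2 the change is chloro in place of hydrogen on an aromatic carbon. Among the measured compounds shown here, the single measured step that bears on this runs the other way, with chloro leaving rather than entering, so its size serves as a rough guide only and the exact magnitude is uncertain. A downward step beyond the scatter is nonetheless expected, of roughly a 2.8-fold lower number from compound 2 to compound 3 (0.45 log units; beyond the scatter). On that basis compound 3 is estimated at 1500 nM in this assay, with a range from 500 nM to 5000 nM.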

Compound 3, half-maximal inhibitory concentration: > 10000 nM
Compound 3 was reported as a limit; the forecaster's own chance of this, stated with the estimate: 5%; middle value at least 6.6-fold (0.82 log units) from the limit.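

In this assay, chloro in place of hydrogen para to a large group moves the number up, not down: an at least 2.3-fold higher number from compound 2 to compound 3 (0.37 log units; beyond the scatter). Within the data shown here, the one earlier step also moved up, but on the loss of chloro, a 5.3-fold higher number from compound 1 to compound 2 (0.72 log units; beyond the scatter), so across these three compounds the direction of a chloro change on this ring depends on where the chloro stands. The reading for compound 3 is a limit of the assay: the limit of > 10000 nM in this assay, at which 1 of the 3 values shown sits.

Still open, from the compounds shown here alone, is whether the rise at this position is particular to chloro or would also follow from another group there, such as fluoro, methyl or methoxy. Going by these compounds, how far compound 3 lies past the limit also stays open, and with it the full size of the step.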